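Cyclohexyl in place of propyl on the carbonyl carbon

The compounds below may be only part of what the source reports. "The series", "measured", "known", "first", "only" and "open" are said of these compounds alone.

Compound 1 `COc1ccc(N)c(C2=NN(C(=O)C3CCCCC3)C(C)(C)S2)c1` — 100%
Compound 2 `CCC(=O)N1N=C(c2ccccc2N)SC1(C)C` — 19.2%
Compound 3 `CCCC(=O)N1N=C(c2ccccc2N)SC1(C)C` — 35.2%

In an assay on isolated protein for inhibition of Nitric oxide synthase, inducible (Homo sapiens), read by scintillation counting, with a stated time of 30 min, tested at 50 uM (a higher number here means more inhibition at the concentration tested (going by the name of the read-out), a lower number less inhibition), compound 3 stands second highest of the three numbers, beyond the scatter above compound 2 and well beneath compound 1. Compound 4 `CC1(C)SC(c2ccccc2N)=NN1C(=O)C1CCCCC1` is still to be measured and differs from compound 3 by cyclohexyl in place of propyl on a carbonyl carbon. Going by the values given here, one measured step bears on this change: a number 16 percentage points higher from compound 2 to compound 3 (beyond the scatter), a modest gain from a larger group on the carbonyl side. Among the compounds with values here, compound 1 also carries the cyclohexyl, but differs from compound 3 in two places, so its value shows only that a cyclohexyl-bearing compound can reach a high number in this assay. A step of a number 26.8 percentage points higher from compound 3 to compound 4 (beyond the scatter) is therefore expected. Compound 4 is estimated at 62% in this assay, within 35% to 90%.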

Compound 4, a percentage reported as inhibition, at one concentration (the size of the read-out at that concentration, not a potency): 28%
Compound 4: middle estimate off by 34 percentage points, on the high side, outside the stated range (below it).
By their numbers in this assay, from the lowest: compounds 2, 4 and 3 (each within the scatter of the next, the first and the last beyond it); then compound 1.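

In this assay cyclohexyl on the carbonyl carbon stands level with the shorter chains, with a number 7.2 percentage points lower from compound 3 to compound 4 (within the scatter) and a number 8.8 percentage points higher from compound 2 to compound 4 (within the scatter). The value of compound 1 is thus not carried by cyclohexyl alone: the large step, hydrogen in place of methoxy on an aromatic carbon, is a number 72 percentage points lower from compound 1 to compound 4 (beyond the scatter). Nothing measured here explains either result. Going by these compounds, whether methoxy would give a similar step with propyl or ethyl on the carbonyl carbon stays open. So does what an amine or a longer chain would give at that place.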